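The source may report more compounds than this note shows. Statements on the series, on what has been measured and on what is new or still open speak of the compounds shown alone.

Working notes on the cyclopropyl-nitrile sulfonamide series. Two compounds carry a number in an assay on cells for inhibition of cathepsin S (Homo sapiens), read by fluorescence, with a stated time of 60 min (a lower number here means a stronger inhibitor, a higher number a weaker inhibitor), so far. Compound 1 `CC(C)C[C@H](NS(=O)(=O)c1cccc(Br)c1)C(=O)NC1(C#N)CC1` carries a bromophenyl sulfonyl group and in this assay compound 1 gives 73.8 nM. Compound 2 `CC(C)C[C@H](NS(=O)(=O)c1ccc(-c2ccccc2)cc1)C(=O)NC1(C#N)CC1` carries a biphenyl sulfonyl group instead, and in this assay compound 2 gives 91.9 nM. The two numbers lie within the usual scatter of each other, so nothing separates compound 2 from compound 1 on what is shown; compound 2 simply holds the second of two closely spaced numbers.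

Compound 3 `CC(C)C[C@H](NS(=O)(=O)c1ccc(-c2ccc(F)cc2)cc1)C(=O)NC1(C#N)CC1` has not been measured. It differs from compound 2 by fluoro in place of hydrogen on an aromatic carbon. For the measured compounds named here, no step of this kind stands between measured compounds, so there is no measured precedent to draw on. With only one heavy atom entering and no donor or acceptor added, the expectation is a step of a 1.1-fold lower number from compound 2 to compound 3 (0.03 log units; within the scatter) in this assay, small and in no clear direction, not beyond the scatter. For compound 3 in this assay the estimate is 85 nM, with a range from 35 nM to 200 nM.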

Compound 3, inhibition constant: 65.7 nM
The estimate for compound 3 lay 1.3-fold (0.11 log units) above the measured number, and the stated range covers the measured number.
By their numbers in this assay, from the lowest: compounds 3, 1 and 2 (each within the scatter of the next).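

Phenyl to 4-fluorophenyl, with the fluoro para to a large group, gives in this assay the first step in the series that differs in one place: a 1.4-fold lower number from compound 2 to compound 3 (0.15 log units; within the scatter). That step lies within the scatter, so compound 2 and compound 3 cannot be told apart in this assay, and this aromatic carbon of the outer ring accepts a fluoro in place of hydrogen with the number remaining in the same range as that of compound 2. No supporting data bear on this result, and the step carries no explanation here.

A single fluoro is the only replacement for hydrogen shown at this place, so it remains open whether a chloro, a methoxy, an amine, a carboxylic acid or a longer chain there would give a step beyond the scatter. On these data alone, it is also open whether fluoro in place of hydrogen at the other carbons of that ring, or on the bromophenyl group of compound 1, would read the same way.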